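The compounds below may be only part of what the source reports. "The series", "measured", "known", "first", "only" and "open" are said of these compounds alone.

Compounds measured in a functional assay on K562 cells (Homo sapiens) for cytotoxicity, read by CCK-8 assay, with a stated time of 72 h; a higher number here means a weaker inhibitor, a lower number a stronger inhibitor:
Compound 1, `C=CCn1c(=O)/c(=C\c2cccc(Br)c2)[nH]c(=O)/c1=C\c1ccccc1OC`, gives 2400 nM.
Compound 2, `C=CCn1c(=O)/c(=C\c2cccc(C)c2)[nH]c(=O)/c1=C\c1ccccc1OC`, gives 8800 nM.

Compound 2 has the highest number of the two; its nearest neighbour is compound 1, and the step of a 3.7-fold higher number from compound 1 to compound 2 (0.56 log units; beyond the scatter) is modest. Compound 3, `C=CCn1c(=O)/c(=C\c2ccccc2F)[nH]c(=O)/c1=C\c1ccccc1OC`, differs from compound 2 by 2-fluorophenyl in place of 3-methylphenyl on a double-bonded chain carbon bound to an aromatic carbon. Among the measured compounds shown here, only that one step bears on this change, and only partly, since it swapped a halogen for methyl on the same aromatic carbon whereas here the halogen enters at a different ring position. A small decrease in number is expected for compound 3, a 1.8-fold lower number from compound 2 to compound 3 (0.25 log units; within the scatter), so compound 3 is estimated at 5000 nM, within 2000 nM to 12000 nM.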

Compound 3, half-maximal inhibitory concentration: 5600 nM
Compound 3: middle estimate off by 1.1-fold (0.05 log units), on the low side; low and high end bracket the measured number.
By their numbers in this assay, from the lowest: compound 1; then compounds 3 and 2 (each within the scatter of the next).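

In this assay, the exchange of 3-methylphenyl for 2-fluorophenyl on the double-bonded chain carbon bound to an aromatic carbon gives a 1.6-fold lower number from compound 2 to compound 3 (0.20 log units; within the scatter) and so does not separate these two groups. The exchange of 3-bromophenyl for 2-fluorophenyl at that place gives a 2.3-fold higher number from compound 1 to compound 3 (0.37 log units; beyond the scatter) and shows that the separation seen earlier for methyl also holds for this fluorinated ring. Compound 1 thus holds the lowest number of the three.

As far as these compounds go, how an amine or a carboxylic acid on this phenyl ring would read remains open. The compounds also leave the identity of the halogen unseparated from its ring position, and no measured evidence accounts for these steps.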